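The compounds below may be only part of what the source reports. "The series", "measured", "known", "first", "only" and "open" are said of these compounds alone.

Measured so far:
compound 1 `Cc1ccc(-c2nnc(-n3[se]c4ccccc4c3=O)s2)cc1` — 16600 nM
compound 2 `O=c1c2ccccc2[se]n1-c1nnc(-c2cccc([N+](=O)[O-])c2)s1` — 27300 nM

In a functional assay on SSMC-7721 cells (Homo sapiens) for antiproliferative activity, read by CCK-8 assay, with a stated time of 48 h (on this read-out lower numbers stand for stronger inhibition and higher numbers for weaker inhibition), compound 1 gives 16600 nM and stands at the lower end of the two numbers shown; compound 2, at 27300 nM, lies within the scatter of it, so the two cannot be separated. Compound 3 `O=c1c2ccccc2[se]n1-c1nnc(-c2ccccc2Br)s1` has not yet been measured. It differs from compound 1 by 2-bromophenyl in place of 4-methylphenyl on an aromatic carbon. Within the data shown here, no measured pair isolates this change, so nothing in the present numbers points to a shift in this assay beyond the scatter in either direction. The step of a 1.2-fold higher number from compound 1 to compound 3 (0.08 log units; within the scatter) is therefore expected to be small. Compound 3 is estimated at 20000 nM, in the range 7000 nM to 55000 nM.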

Compound 3, half-maximal inhibitory concentration: 27400 nM
Estimate against measurement, compound 3: 1.4-fold (0.14 log units) below; the range from low to high includes it.
By their numbers in this assay, from the lowest: compounds 1, 2 and 3 (each within the scatter of the next).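

In this assay, 2-bromophenyl in place of 4-methylphenyl on this aromatic carbon gives a 1.7-fold higher number from compound 1 to compound 3 (0.22 log units; within the scatter), the first step read at this position, and it shows no separable change. This single step alters both the substituent and its place on the phenyl ring, and the two contributions cannot be told apart. No measurement at hand speaks to the reason for this result.

Open, as far as these compounds go, is whether a phenyl group carrying an amine or a carboxylic acid would move the number beyond the scatter. A longer alkyl chain in place of the aryl group is equally untested among the compounds shown.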